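A few compounds are considered here, and "the series" means these few. Any claim that something is new, unique, unknown or untested is made for them only; others in the source may bear on it.

In a functional assay on QGY-7703 cells (Homo sapiens) for cytotoxicity, read by MTT assay, with a stated time of 24 h (on this read-out higher numbers stand for weaker inhibition and lower numbers for stronger inhibition), compound 1 `O=C1/C(=C/c2cccnc2)CNC/C1=C\c1ccccc1F` gives 8890 nM, compound 2 `O=C1/C(=C/c2cccnc2)CN(S(=O)(=O)c2ccc([N+](=O)[O-])cc2)C/C1=C\c1ccccc1F` gives 5600 nM, and compound 3 `O=C1/C(=C/c2cccnc2)CN(S(=O)(=O)c2ccc(C(F)(F)F)cc2)C/C1=C\c1ccccc1F` gives 4500 nM. Compound 3 therefore stands within the usual scatter of both other compounds, so these three numbers cannot be ranked. Compound 4 `O=C1/C(=C/c2cccnc2)CN(S(=O)(=O)c2ccc(F)cc2)C/C1=C\c1ccccc1F` differs from compound 3 in one place: fluoro in place of trifluoromethyl on an aromatic carbon, with fluoro in place of trifluoromethyl on an aromatic carbon. Within the data shown here, one measured step bears on this change, a swap of trifluoromethyl in place of nitro on an aromatic carbon: a 1.2-fold lower number from compound 2 to compound 3 (0.09 log units; within the scatter). That step stayed within the scatter, so no step beyond the scatter is expected in this assay. The expected change is a 1.1-fold higher number from compound 3 to compound 4 (0.05 log units; within the scatter). For compound 4 the estimated value is 5000 nM, with an expected range from 2500 nM to 10000 nM.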

Compound 4, half-maximal inhibitory concentration: 15300 nM
Compound 4: the middle estimate sits 3.1-fold (0.49 log units) below what was measured; the measured number lies above the stated range.
By their numbers in this assay, from the lowest: compounds 3, 2, 1 and 4 (each within the scatter of the next, the first and the last beyond it).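

The group on this aromatic ring does matter: fluoro in place of trifluoromethyl gives a 3.4-fold higher number from compound 3 to compound 4 (0.53 log units; beyond the scatter) and fluoro in place of nitro gives a 2.7-fold higher number from compound 2 to compound 4 (0.44 log units; beyond the scatter) on a read-out where higher numbers mean weaker inhibition. Adding (4-fluorophenyl)sulfonyl to the ring amine nitrogen gives a 1.7-fold higher number from compound 1 to compound 4 (0.24 log units; within the scatter) and so shows no clear change. Nothing measured here explains why fluoro parts from the other two groups. Going by these compounds, whether an amine, a methoxy group or a carboxylic acid at this ring carbon would match compound 3 remains open.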